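From Chloro to Hydroxy at the Assay Limit

The compounds below may be only part of what the source reports. "The series", "measured", "known", "first", "only" and "open" are said of these compounds alone.

In a toxicity assay on HaCaT cells (Homo sapiens) for inhibition, read by MTT assay, with a stated time of 72 h (on this read-out lower numbers stand for stronger inhibition of growth and higher numbers for weaker inhibition of growth), compound 1 `O=C1CC(N2C(=O)CSC2=S)C(=O)N1c1ccc(Cl)cc1` gives 97700 nM. Compound 2 `O=C1CC(N2C(=O)/C(=C/C(Cl)=C/c3ccc([N+](=O)[O-])cc3)SC2=S)C(=O)N1c1ccc(Cl)cc1` reaches only a limit of the assay, > 100000 nM, so it has no exact number. Compound 3 `O=C1CC(N2C(=O)/C(=C/C(Cl)=C/c3ccc([N+](=O)[O-])cc3)SC2=S)C(=O)N1c1ccc(O)cc1` carries hydroxy in place of the chloro of compound 2 on an aromatic carbon (hydroxy in place of chloro on an aromatic carbon), turning 4-chlorophenyl into 4-hydroxyphenyl. Within the data shown here, no measured step between compounds bears on this change in this assay, and no shift beyond the scatter is expected in either direction. The expected step of a number no higher from compound 2 to compound 3 (the limit leaves the size open) is therefore small. For compound 3 the estimated value is 100000 nM, with an expected range from 35000 nM to 200000 nM.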

Compound 3, concentration for 50% growth inhibition: 73600 nM
Beside the measured number, compound 3's estimate is 1.4-fold (0.13 log units) above it; low and high end bracket the measured number.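

In this assay, hydroxy in place of chloro on the aromatic carbon gives an at least 1.3-fold lower number from compound 2 to compound 3 (0.13 log units; that floor lies within the scatter). Of the two compounds carrying the longer group on the shared core, compound 3 alone has an exact number, 73600 nM. The full size of the step cannot be read because compound 2 stands at a limit and not at a number: the limit of > 100000 nM in this assay, at which 1 of the 3 values shown sits.

The compounds shown leave open how an amine or a methoxy group at this position would compare with hydroxy in this assay. Going by these compounds, whether the same change would shift the number of compound 1 also stays open.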